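The source may hold more compounds than are shown below. What is called first, only, known or untested is meant among the compounds shown, and "the series" means these compounds.

Working notes on the series in a functional assay on DU-145 cells (Homo sapiens) for inhibition, read by trypan blue exclusion, with a stated time of 96 h; on this read-out higher numbers stand for weaker inhibition of growth and lower numbers for stronger inhibition of growth.

Of the compounds shown here, three carry a number so far. Compound 1 `O=C(/C(=C/c1ccc(Cl)cc1)Cc1c[nH]c2ccccc12)c1ccc(Cl)cc1Cl` gives 10000 nM in this assay. Compound 2 `COc1cc(OC)c(/C=C(\C(=O)c2ccc(Cl)cc2)S(=O)(=O)Cc2ccc(F)cc2)c(OC)c1` gives 25000 nM in this assay. Compound 3 `O=C(/C(=C\c1ccc(O)cc1O)SCc1ccc(Cl)cc1)c1ccc(Cl)cc1` gives 50000 nM in this assay. Compound 2 stands second highest of the three numbers: the value of compound 3 lies within the usual scatter of it, so no ordering between the two is claimed, while compound 1 sits at a lower number, and that gap lies beyond the scatter.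

The next compound, compound 4 `COc1cc(OC)c(/C=C(/SCc2ccc(Cl)cc2Cl)C(=O)c2ccc(Cl)cc2)c(OC)c1`, has not yet been measured in this assay. Its structure differs from compound 2 in one place, with the sulfur and the benzyl substitution both altered: (2,4-dichlorobenzyl)sulfanyl in place of (4-fluorobenzyl)sulfonyl on a double-bonded chain carbon bound to a carbonyl carbon and a double-bonded chain carbon

Among the measured compounds shown here, no measured pair in the set differs by this change alone, so there is no comparable step to lean on. Compound 3 carries a benzylsulfanyl group and shares the dichlorophenyl ketone with compound 2, yet its other ring differs, so it gives only loose guidance. For compound 4 the expectation is a step of a 1.3-fold lower number from compound 2 to compound 4 (0.10 log units; within the scatter), which is not expected to exceed the scatter. Compound 4 is estimated at 20000 nM in this assay, with a range from 6000 nM to 60000 nM.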

Compound 4, concentration for 50% growth inhibition: 1000 nM
For compound 4 the middle estimate is 20-fold (1.30 log units) above the measured one; measured number below the stated range.
By their numbers in this assay, from the lowest: compound 4; then compound 1; then compounds 2 and 3 (each within the scatter of the next).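

In this assay the place on the double-bonded chain carbon bound to a carbonyl carbon and a double-bonded chain carbon proves highly responsive: (2,4-dichlorobenzyl)sulfanyl in place of (4-fluorobenzyl)sulfonyl gives a 25-fold lower number from compound 2 to compound 4 (1.40 log units; beyond the scatter). Among the compounds shown here, this is the only step that can be read, and it shows that a change in this one place on the shared core can move the number well beyond the scatter. Nothing available on these compounds accounts for the size of this step.

The step alters the sulfur and the benzyl substitution together, and the compounds shown leave open how much of it belongs to each; (4-fluorobenzyl)sulfanyl or (2,4-dichlorobenzyl)sulfonyl at this place would separate the two. Also open, going by these compounds, is whether a benzyl group carrying an amine or a carboxylic acid would hold the lower number.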